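The source may hold more compounds than are shown below. What is called first, only, known or untested is meant among the compounds shown, and "the series" means these compounds.

Measured in a functional assay on DU-145 cells (Homo sapiens) for inhibition, read by trypan blue exclusion, with a stated time of 72 h; a lower number here means a stronger inhibitor, a higher number a weaker inhibitor:
- compound 1 `COc1ccc(Nc2ncc3cc(S(=O)(=O)c4ccc(Cl)cc4)c(=O)n(C)c3n2)cc1`: 30000 nM
- compound 2 `Cn1c(=O)c(S(=O)(=O)c2ccc(Cl)cc2)cc2cnc(Nc3ccc4[nH]ccc4c3)nc21`: 250 nM
- compound 3 `Cc1ccc(S(=O)(=O)c2cc3cnc(Nc4cnc5[nH]ccc5c4)nc3n(C)c2=O)cc1`: 25000 nM

Compound 3, at 25000 nM, lies within the scatter of compound 1 and far from the much lower value of compound 2, 250 nM.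

Compound 4 `Cn1c(=O)c(S(=O)(=O)c2ccc(Cl)cc2)cc2cnc(Nc3cnc4[nH]ccc4c3)nc21` differs from compound 3 by chloro in place of methyl on an aromatic carbon, which is chloro in place of methyl on an aromatic carbon, or 4-methylphenyl to 4-chlorophenyl.

Among the measured compounds shown here, the only measured single-place step, a 120-fold lower number from compound 1 to compound 2 (2.08 log units; beyond the scatter), is large but concerns 1H-indol-5-yl in place of 4-methoxyphenyl on a nitrogen, not this position. For the measured compounds named here, no measured step covers the methyl to chloro swap itself. Compound 4 carries the same (4-chlorophenyl)sulfonyl as compound 1, and compound 1 still gives 30000 nM, so that group offers no reason to expect a large drop. No step beyond the scatter is therefore expected, though the range stays wide and leans towards lower numbers. The expected change is a 1.7-fold lower number from compound 3 to compound 4 (0.22 log units; within the scatter). For compound 4 the estimate is 15000 nM, with an expected range of 2500 nM to 40000 nM.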

Compound 4, half-maximal inhibitory concentration: 5000 nM
Compound 4: the middle estimate sits 3.0-fold (0.48 log units) above what was measured, and the stated range covers the measured number.
By their numbers in this assay, from the lowest: compound 2; then compound 4; then compounds 3 and 1 (each within the scatter of the next).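

In this assay the position on the sulfonyl-bearing phenyl ring responds to a single-atom swap: 4-methylphenyl to 4-chlorophenyl gives a 5.0-fold lower number from compound 3 to compound 4 (0.70 log units; beyond the scatter) and lies beyond the scatter, though the step is only modest. With (4-chlorophenyl)sulfonyl held constant, changing the group on the nitrogen gives a 20-fold higher number from compound 2 to compound 4 (1.30 log units; beyond the scatter) and a 6.0-fold lower number from compound 1 to compound 4 (0.78 log units; beyond the scatter), the first large and the second modest, so compound 2 remains the lowest of the three and the group on the nitrogen still matters once chloro is in place. No measurement at hand accounts for the difference between chloro and methyl here.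

On these data alone, it remains open whether methyl to chloro gives a step of similar size with 1H-indol-5-yl on the nitrogen. Also open, as far as these compounds go, is how an amine, a carboxylic acid or a longer chain at this position would compare with chloro.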